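The source may report more compounds than this note shows. Statements on the series, on what has been measured and on what is new or still open speak of the compounds shown alone.

Compound 1 `COc1cc(Cl)c(-c2nc(SCC(=O)NC3CC3)nc3[nH]cc(C#N)c23)cc1O`: 236 nM
Compound 2 `CCOc1cc(-c2nc(SCC(=O)NC3CC3)nc3[nH]cc(C#N)c23)c(Cl)cc1OC`: 23 nM

Both values come from a functional assay on MDA-MB-468 cells (Homo sapiens) for antiproliferative activity, read by sulforhodamine B assay, with a stated time of 4 days; a higher number here means a weaker inhibitor of growth, a lower number a stronger inhibitor of growth. Compound 2 holds the lower of the two numbers, and the gap to compound 1 lies beyond the scatter. The next compound, compound 3 `CCNC(=O)CSc1nc(-c2cc(OCC)c(OC)cc2Cl)c2c(C#N)c[nH]c2n1`, keeps everything in compound 2 except the group on the amide. The change is ethyl in place of cyclopropyl on an amide-type nitrogen.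

Among the compounds with values here, only one measured step exists, a 10-fold lower number from compound 1 to compound 2 (1.01 log units; beyond the scatter). It is large, but it records ethyl in place of hydrogen on an oxygen on an aromatic ring, a different place from the amide-type nitrogen. Both measured compounds carry the cyclopropyl, so no measurement shows what losing it does in this assay. With no evidence for a large change, no step beyond the scatter is expected, although the uncertainty is wide. The expectation therefore starts from compound 2 at 23 nM.

The expected step is a 1.3-fold higher number from compound 2 to compound 3 (0.12 log units; within the scatter). For compound 3 the estimated value is 30 nM, with an expected range of 10 nM to 90 nM.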

Compound 3, concentration for 50% growth inhibition: 64 nM
For compound 3 the middle estimate is 2.1-fold (0.33 log units) below the measured one, within the range that was stated.
By their numbers in this assay, from the lowest: compound 2; then compound 3; then compound 1.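

In this assay, ethyl in place of cyclopropyl on the amide-type nitrogen gives a 2.8-fold higher number from compound 2 to compound 3 (0.44 log units; beyond the scatter), a modest step but one beyond the scatter. Within the data shown here, this is the first reading at this position, as compound 1 and compound 2 both carry the cyclopropyl, and it shows that the group on the amide-type nitrogen is not indifferent: the open two-carbon ethyl does not fully match the three-carbon ring of compound 2. No measurement at hand accounts for the step.

Ethyl differs from cyclopropyl both in having no ring and in having one carbon fewer, so this single pair cannot tell whether the ring or the carbon count matters. An isopropyl group, which has the three carbons of cyclopropyl without the ring, or a cyclobutyl group on the same nitrogen would separate the two, while a longer chain ending in an amine or a carboxylic acid would test how much else this position accepts.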